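The source may hold more compounds than are shown below. What is called first, only, known or untested is meant among the compounds shown, and "the series" means these compounds.

Measured so far:
compound 1, `COc1ccc(C(=O)Nc2cc(-c3ccccc3)nn2-c2ccccc2)cc1`, 420 nM
compound 2, `O=C(Nc1cc(-c2ccccc2)nn1-c1ccccc1Cl)c1ccccc1`, 500 nM

Of the compounds shown here, two have been measured in an assay on HEK293 cells for displacement of a labelled ligand from metabotropic glutamate receptor 5 (Rattus norvegicus); on this read-out lower numbers stand for stronger inhibition and higher numbers for weaker inhibition. Compound 1 is `COc1ccc(C(=O)Nc2cc(-c3ccccc3)nn2-c2ccccc2)cc1` and gives 420 nM. Compound 2 is `O=C(Nc1cc(-c2ccccc2)nn1-c1ccccc1Cl)c1ccccc1` and gives 500 nM, the higher of the two numbers, though the gap to compound 1 lies within the scatter, so the two stand level as far as these data show.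

The next compound, compound 3, is `N#Cc1cccc(-n2nc(-c3ccccc3)cc2NC(=O)c2ccccc2)c1`. It differs from compound 2 in one place: 3-cyanophenyl in place of 2-chlorophenyl on an aromatic nitrogen. Among the measured compounds shown here, no measured pair shows the effect of this particular exchange, so there is no direct precedent in the data for the size of the step. The two measured compounds differ in two places at once and give nearly the same number, which offers no guide on its own.

With only that to go on, compound 3 is expected to come out near compound 2, with a step of a 1.4-fold lower number from compound 2 to compound 3 (0.15 log units; within the scatter) that may be toward a somewhat lower number but need not exceed the scatter. The estimate for compound 3 in this assay is 350 nM, with a range from 90 nM to 1400 nM.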

Compound 3, inhibition constant: > 10000 nM
Compound 3: a limit, no number; the forecaster's own chance of this, stated with the estimate: 3%; middle value at least 28-fold (1.45 log units) from the limit.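

In this assay compound 3 gives > 10000 nM, which is a limit of the assay and not a number. The aromatic nitrogen, next to the ring atom that bears a benzamido group, proves to be a place where the choice of aryl group can matter greatly: 3-cyanophenyl in place of 2-chlorophenyl brings an at least 20-fold higher number from compound 2 to compound 3 (1.30 log units; beyond the scatter), a difference that the level pair of compound 1 and compound 2 gave no sign of. Only the minimum size of this step can be read, and its full size stays unknown: the limit of > 10000 nM in this assay, at which 1 of the 3 values shown sits.

The compounds shown change the group on this aryl ring and its location together, so they leave open whether the loss of the chlorine, the entry of the nitrile or the different location carries the step. Also open, as far as these compounds go, is how this series would respond to a carboxylic acid, an amine or a methoxy group in the place of the nitrile, and so whether the loss seen here belongs to the nitrile alone or extends to other groups on that ring.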